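This account rests on a few compounds, and the source may have more. Where it says the series, first, only, none or still open, it means among the compounds named here.

In an ADME assay on a cell-free system (plasma, Homo sapiens) for metabolic stability, with Plasma (Rattus norvegicus) as the target, read by HPLC, at pH 7.4 (a higher number here means that the compound lasts longer, a lower number that the compound disappears faster), the measured compounds are:
compound 1 `CC(=O)Oc1ccccc1C(=O)O[C@H]1CO[C@H]2[C@@H]1OC[C@H]2OC(=O)c1ccc(C)cc1` with 0.0362 h;
compound 2 `CC(=O)Oc1ccccc1C(=O)O[C@H]1CO[C@H]2[C@@H]1OC[C@H]2OC(=O)c1ccccc1OC(=O)c1ccccc1` with 0.0722 h;
compound 3 `CC(=O)Oc1ccccc1C(=O)O[C@H]1CO[C@H]2[C@@H]1OC[C@H]2OC(=O)c1cccnc1` with 0.00617 h.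

On these numbers compound 1 holds the second highest value; compound 2 lies within the scatter of it, while compound 3 stands apart by a 5.9-fold lower number from compound 1 to compound 3 (0.77 log units; beyond the scatter). Compound 4 `CC(=O)Oc1ccccc1C(=O)O[C@H]1CO[C@H]2[C@@H]1OC[C@H]2OC(=O)c1ccc(CO[N+](=O)[O-])cc1` differs from compound 1 by nitrooxy in place of hydrogen on a saturated chain carbon bound to an aromatic carbon. Within the data shown here, the only measured step, a 5.9-fold lower number from compound 1 to compound 3 (0.77 log units; beyond the scatter), exchanges the whole aromatic ring rather than adding a group to the methyl, so it gives no direct guide to this change. Among the measured compounds shown here, with no matching precedent, no step beyond the scatter is expected in this assay. Compound 4 is therefore estimated at 0.03 h, with a range from 0.012 h to 0.08 h. That expectation corresponds to a 1.2-fold lower number from compound 1 to compound 4 (0.08 log units; within the scatter).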

Compound 4, half-life: 0.04 h
Compound 4: the middle estimate sits 1.3-fold (0.12 log units) below what was measured; the measured number falls inside the stated range.
By their numbers in this assay, from the lowest: compound 3; then compounds 1, 4 and 2 (each within the scatter of the next).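

Nitrooxy in place of hydrogen on a saturated chain carbon bound to an aromatic carbon gives a 1.1-fold higher number from compound 1 to compound 4 (0.04 log units; within the scatter) in this assay and so shows that this position accepts the group without a change beyond the scatter. The pyridin-3-yl compound remains apart, with 4-((nitrooxy)methyl)phenyl in its place giving a 6.5-fold higher number from compound 3 to compound 4 (0.81 log units; beyond the scatter) on the same carbonyl carbon. No measurement shown here gives a reason for either result. Still open, going by these compounds, is whether an amine or a carboxylic acid at this carbon, or a longer chain carrying the nitrooxy, would leave the half-life equally unmoved.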